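The source may hold more compounds than are shown below. What is called first, only, known or untested is meant among the compounds shown, and "the series" means these compounds.

Of the compounds shown here, three built on one shared core have been tested in a functional assay on Huh7.5.1 cells (Homo sapiens) for cytotoxicity, read by MTT assay, with a stated time of 72 h; on this read-out lower numbers stand for higher toxicity in this test and higher numbers for lower toxicity in this test: compound 1 (`C=c1[nH]c(=O)/c(=C/c2c[nH]c3ccccc23)[nH]c1=O`), compound 2 (`C=c1[nH]c(=O)/c(=C/c2ccccc2)[nH]c1=O`) and compound 3 (`C=c1[nH]c(=O)/c(=C/c2cc(C(C)(C)C)cc(C(C)(C)C)c2)[nH]c1=O`). Compound 1 gives > 20000 nM, which is a limit of the assay and not a number. As far as these compounds go, compound 2 gives > 20000 nM, which is likewise only a limit, so its true position on this scale remains unknown. The whole set so far stands at one point: the limit of > 20000 nM in this assay, at which 3 of the 3 values shown sit.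

Compound 4 (`C=c1[nH]c(=O)/c(=C/c2ccc(C(C)(C)C)cc2)[nH]c1=O`) has yet to be measured. It departs from compound 2 by a single change, tert-butyl in place of hydrogen on an aromatic carbon. The nearest guide is compound 3, which also carries tert-butyl on its six-membered aromatic ring of carbon only, and compound 3 gives > 20000 nM, again a limit. Among the measured compounds shown here, with no measured step available in this assay, the expectation rests on these limits alone, and no change beyond the usual scatter is expected. The expected size of the move is a number no higher from compound 2 to compound 4 (the limit leaves the size open). For compound 4 the estimate is 20000 nM, with an expected range from 10000 nM to 40000 nM, and the reading is expected most likely to be a limit once more.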

Compound 4, half-maximal cytotoxic concentration: > 20000 nM
Compound 4: a limit, no number (the forecaster's own chance of this, stated with the estimate: 80%); the middle value sits exactly at the limit.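

Compound 2 and compound 4 each give only a limit and not a number, and the step between them cannot be read. The compounds shown leave open where any of them truly stands on this scale, and whether tert-butyl in place of hydrogen on an aromatic carbon changes the read-out at all, with the whole set at one point: the limit of > 20000 nM in this assay, at which 4 of the 4 values shown sit.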